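From Nitrofuran to Nitrophenyl: Rat Plasma Exposure

The source may report more compounds than this note shows. Statements on the series, on what has been measured and on what is new or still open speak of the compounds shown alone.

Two compounds share one core and differ only in the aryl group on a saturated chain carbon bound to an amine nitrogen in a ring. Compound 1 `Nc1ccc(CN2CCN(c3ccc(N4C[C@H](Cn5ccnn5)OC4=O)cc3F)CC2)cc1` carries a 4-aminophenyl group there, and in an in vivo ADME assay on the whole organism (strain Sprague-Dawley) for pharmacokinetics, with Rattus norvegicus as the target, at a dose of 50 mg/kg by the oral route (a higher number here means more compound in the circulation at the dose given, a lower number less compound in the circulation), compound 1 gives 5140 nM. Compound 2 `O=C1O[C@@H](Cn2ccnn2)CN1c1ccc(N2CCN(Cc3ccc([N+](=O)[O-])o3)CC2)c(F)c1` carries a 5-nitrofuran-2-yl group instead; in this assay compound 2 gives 35800 nM, the higher of the two numbers, and the step of a 7.0-fold higher number from compound 1 to compound 2 (0.84 log units; beyond the scatter). Compound 3 `O=C1O[C@@H](Cn2ccnn2)CN1c1ccc(N2CCN(Cc3cccc([N+](=O)[O-])c3)CC2)c(F)c1` is not yet measured. Its change from compound 2 is 3-nitrophenyl in place of 5-nitrofuran-2-yl on a saturated chain carbon bound to an amine nitrogen in a ring. For the measured compounds named here, only one measured step bears on this position, a 7.0-fold higher number from compound 1 to compound 2 (0.84 log units; beyond the scatter), and it shows that swapping the aryl group here can move the number beyond the scatter. Going by the values given here, both compound 2 and compound 3 keep a nitro group on that aryl ring; no measured step tells how the ring itself matters. Compound 3 is therefore expected to give 20000 nM (range 7000 nM to 55000 nM), meaning a 1.8-fold lower number from compound 2 to compound 3 (0.25 log units; within the scatter).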

Compound 3, maximal plasma concentration: 22400 nM
Estimate against measurement, compound 3: 1.1-fold (0.05 log units) below; the range from low to high includes it.
By their numbers in this assay, from the lowest: compound 1; then compounds 3 and 2 (each within the scatter of the next).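

In this assay the exchange of 5-nitrofuran-2-yl for 3-nitrophenyl brings a 1.6-fold lower number from compound 2 to compound 3 (0.20 log units; within the scatter) and so, at this position, a five-membered aromatic ring with one hetero atom and a six-membered aromatic ring of carbon only cannot be told apart. The 4-aminophenyl group still stands apart: a 4.4-fold higher number from compound 1 to compound 3 (0.64 log units; beyond the scatter) is a second step beyond the scatter, and both nitro-bearing groups give the higher numbers among these three compounds. No measurement shown here offers an explanation for either step.

From the compounds shown here alone, it remains open whether the nitro group itself accounts for the gap to compound 1, as 3-nitrophenyl and 4-aminophenyl differ in both the group on the ring and its place. An unsubstituted phenyl group or a 4-nitrophenyl group at this position would help separate those two changes.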